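Cyclopentyl for methyl on the weakest of three binders

The compounds below may be only part of what the source reports. "The series", "measured", "known", "first", "only" and "open" are said of these compounds alone.

Compound 1, `COc1ccc(/C=C2\NC(=O)N(CCCN3CCN(c4cccc(Cl)c4Cl)CC3)C2=O)cc1OC`, gives 22 nM in an assay on CHO cells for displacement of a labelled ligand from 5-hydroxytryptamine receptor 7 (Homo sapiens), read by scintillation counting, with a stated time of 60 min; on this read-out lower numbers stand for stronger inhibition and higher numbers for weaker inhibition.
Compound 2, `COc1ccc(/C=C2\NC(=O)N(CCCCN3CCN(c4cccc(Cl)c4Cl)CC3)C2=O)cc1OC`, gives 0.8 nM in this assay.
Compound 3, `COc1ccc(/C=C2\NC(=O)N(CCCCN3CCN(c4ncccn4)CC3)C2=O)cc1OC`, gives 933 nM in this assay.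

Compound 3 stands highest of the three numbers in this assay; the step of a 1200-fold higher number from compound 2 to compound 3 (3.07 log units; beyond the scatter) separates it from compound 2, and compound 1 lies between the two. Compound 4, `COc1ccc(/C=C2\NC(=O)N(CCCCN3CCN(c4ncccn4)CC3)C2=O)cc1OC1CCCC1`, keeps the whole of compound 3 and changes it in one place: cyclopentyl in place of methyl on an oxygen on an aromatic ring. Within the data shown here, none of the measured steps bears on this change. The only step shown, a 1200-fold higher number from compound 2 to compound 3 (3.07 log units; beyond the scatter), concerns the group on the amine nitrogen in the ring, which compound 4 leaves untouched, and no pair of measured compounds differs at the oxygen on the aromatic ring. With nothing to lean on, the expectation for compound 4 in this assay is a step of a 1.0-fold lower number from compound 3 to compound 4 (0.02 log units; within the scatter), that is, no change beyond the scatter in either direction, with a wide range to cover the unknown. Compound 4 is therefore estimated at 900 nM, between 250 nM and 3500 nM.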

Compound 4, inhibition constant: 298 nM
The estimate for compound 4 lay 3.0-fold (0.48 log units) above the measured number; measured number inside the range.
By their numbers in this assay, from the lowest: compound 2; then compound 1; then compound 4; then compound 3.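

In this assay, among these compounds, the oxygen on the aromatic ring turns out to be a place that responds: cyclopentyl in place of methyl gives a 3.1-fold lower number from compound 3 to compound 4 (0.50 log units; beyond the scatter), the first measured change at this position, modest but beyond the scatter. The larger group is therefore tolerated on the pyrimidin-2-yl compound, yet this step is far smaller than a 1200-fold higher number from compound 2 to compound 3 (3.07 log units; beyond the scatter), so the group on the amine nitrogen in the ring remains the change with the larger measured effect. Nothing shown accounts for the gain at the oxygen.

From the compounds shown here alone, it remains open whether the same change would move the 2,3-dichlorophenyl compound 2 by a similar step. Also open, going by these compounds, is how an ethyl, isopropyl or cyclohexyl group on that oxygen, or a free hydroxyl in place of the methoxy, would compare with cyclopentyl.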